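Amine variation on the benzyloxy chromone, antiproliferative read

The compounds below may be only part of what the source reports. "The series", "measured", "known", "first", "only" and "open" are said of these compounds alone.

Compound 1 `O=c1cc(-c2ccccc2)oc2cc(OCc3ccccc3)c(OCCCN3CCCC3)c(O)c12` is the benzyloxy member of the series. In a functional assay on BCG823 cells (Homo sapiens) for antiproliferative activity, read by MTT assay, with a stated time of 48 h (on this read-out lower numbers stand for stronger inhibition and higher numbers for weaker inhibition), compound 1 gives > 100000 nM, which is a limit of the assay and not a number. Compound 2 `O=c1cc(-c2ccccc2)oc2cc(O)c(OCCCN3CCCC3)c(O)c12` carries hydrogen in place of benzyl on an oxygen on an aromatic ring. In this assay compound 2 gives > 100000 nM, again a limit rather than a measured number. The step that the two limits leave unreadable from compound 1 to compound 2 accordingly cannot be sized, since both values sit at the limit of > 100000 nM in this assay, at which 2 of the 2 values shown sit. Compound 3 `CCN(CC)CCCCOc1c(OCc2ccccc2)cc2oc(-c3ccccc3)cc(=O)c2c1O` is the unmeasured member. Its difference from compound 1 is (diethylamino)methyl in place of pyrrolidin-1-yl on a saturated chain carbon, three bonds along the chain from an oxygen on an aromatic ring. Going by the values given here, no measured step touches the amine end of the chain, so the only evidence bearing on the change is the pair of limits at the limit of > 100000 nM in this assay, at which 2 of the 2 values shown sit, which shows no readable potency anywhere so far. On that basis compound 3 is expected to show a step that the limit leaves unreadable from compound 1 to compound 3 that is not readable against the scatter and to stay at the limit. The estimate for compound 3 in this assay is 150000 nM, with a range from 50000 nM to 500000 nM.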

Compound 3, half-maximal inhibitory concentration: 4200 nM
For compound 3 the middle estimate is 36-fold (1.55 log units) above the measured one; the whole stated range lies above it.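

Amine end of the chain, first readable step: in this assay the change from 3-(pyrrolidin-1-yl)propyl to 4-(diethylamino)butyl gives an at least 23-fold lower number from compound 1 to compound 3 (1.37 log units; beyond the scatter), so the position responds strongly to what is placed there. The benzyloxy group and the shared core stay as in compound 1, which ties this step to the chain end alone, whereas the step on the benzyl oxygen cannot be read. Until compound 3 the series offered no measured number to compare: the limit of > 100000 nM in this assay, at which 2 of the 3 values shown sit.

The step joins two differences, the ring of pyrrolidin-1-yl opened to diethylamino and a longer chain, and the compounds shown do not separate them; 3-(diethylamino)propyl or 4-(pyrrolidin-1-yl)butyl on the same oxygen would do so. Also open, going by these compounds, are whether the benzyl group still matters with 4-(diethylamino)butyl in place, which a free hydroxyl there would show, and how other amines at the end of the butyl chain, such as piperidine or morpholine, compare with diethylamino.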